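The source may report more compounds than this note shows. Statements on the series, on what has been measured and on what is new or still open speak of the compounds shown alone.

Compound 1 `Cc1ccc(N(CCN2CCC(OCC(=O)O)CC2)C(=O)c2cccc(Cl)c2)cc1`: 100 nM
Compound 2 `Cc1ccc(N(CCN2CCC(OCC(=O)O)CC2)C(=O)c2cccc(C)c2)cc1`: 160 nM
Compound 3 `Cc1ccc(N(CCN2CCC(OCC(=O)O)CC2)C(=O)c2cccc(C(F)(F)F)c2)cc1`: 20000 nM

All three values come from a functional assay on a cell-free system (Platelet, plasma, Homo sapiens) for inhibition; on this read-out lower numbers stand for stronger inhibition and higher numbers for weaker inhibition. Compound 1 stands at the low end of this small set, although compound 2 keeps level with it within the scatter, while compound 3 lies far higher. The unmeasured compound 4 `O=C(O)COC1CCN(CCN(C(=O)c2cccc(Cl)c2)c2ccc(Cl)cc2)CC1` departs from compound 1 by one exchange, (chloro in place of methyl on an aromatic carbon), which is chloro in place of methyl on an aromatic carbon, para to a large group, turning 4-methylphenyl into 4-chlorophenyl.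

Going by the values given here, no measured step covers this place in the molecule, so the evidence is indirect. Among the compounds with values here, the closest precedent exchanges the same two groups elsewhere, and it gave a 1.6-fold higher number from compound 1 to compound 2 (0.20 log units; within the scatter). Trifluoromethyl at that same other place gave far larger steps, a 200-fold higher number from compound 1 to compound 3 (2.30 log units; beyond the scatter) and a 130-fold higher number from compound 2 to compound 3 (2.10 log units; beyond the scatter), so a single replacement in this series can matter greatly. With compound 2 as the main guide, at 160 nM, no change beyond the scatter is expected, though the range is kept wide. The expected step is no change at the digits printed from compound 1 to compound 4 (within the scatter). Compound 4 is estimated at 100 nM, with an expected range of 30 nM to 400 nM.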

Compound 4, half-maximal inhibitory concentration: 350 nM
For compound 4 the middle estimate is 3.5-fold (0.54 log units) below the measured one; low and high end bracket the measured number.
By their numbers in this assay, from the lowest: compounds 1 and 2 (each within the scatter of the next); then compound 4; then compound 3.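

In this assay, the exchange of 4-methylphenyl for 4-chlorophenyl gave a 3.5-fold higher number from compound 1 to compound 4 (0.54 log units; beyond the scatter), so this place on the core of compound 1 responds to a change of a single heavy atom, with weaker inhibition after the exchange. The same two groups at the other place gave a 1.6-fold higher number from compound 1 to compound 2 (0.20 log units; within the scatter), which lies within the scatter, so in these compounds methyl and chloro cannot be treated as equivalent at every place. The new step is modest beside a 200-fold higher number from compound 1 to compound 3 (2.30 log units; beyond the scatter), and inhibition remains measurable in the same assay after the exchange. No measured evidence bears on why this exchange weakens inhibition.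

The compounds shown leave open how a fluoro, a methoxy or an amine would read at this place, and whether trifluoromethyl would produce as large a step here as it did at the other place. They also leave open whether the size of this step would hold with methyl rather than chloro at the other place.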